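Notes on the step from compound 3 to compound 4

The source may hold more compounds than are shown below. What is called first, only, known or untested is meant among the compounds shown, and "the series" means these compounds.

Measured in a functional assay on HT-29 cells (Homo sapiens) for antiproliferative activity, read by XTT assay, with a stated time of 72 h; on this read-out lower numbers stand for stronger inhibition and higher numbers for weaker inhibition:
- compound 1 `C=C(C)CC[C@]1(C)C2=CCC[C@](C)(C[C@H](O)c3ccoc3)[C@H]2CC[C@H]1C` gives 30000 nM
- compound 2 `C=C(C)CC[C@]1(C)C2=CCC[C@](C)(C[C@@H](O)C3=CC(=O)OC3O)[C@H]2CC[C@H]1C` gives 3600 nM
- compound 3 `C=C(C)CC[C@]1(C)C2=CCC[C@](C)(C[C@H](O)C3=CC(=O)OC3O)[C@H]2CC[C@H]1C` gives 3200 nM

Not yet measured: compound 4 `C=C(C)CC[C@]1(C)C2=CCC[C@](C)(C[C@@H](O)c3ccoc3)[C@H]2CC[C@H]1C`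

Compound 3 stands with compound 2 at the low end of the three numbers, and the two lie within the scatter of each other (a 1.1-fold lower number from compound 2 to compound 3 (0.05 log units; within the scatter)). Compound 1 is clearly apart from it (a 9.4-fold lower number from compound 1 to compound 3 (0.97 log units; beyond the scatter)).

The change to compound 4 is a group of 7 heavy atoms (5 carbon, 2 oxygen; one five-membered aromatic ring with 1 hetero atom) in place of a group of 9 heavy atoms (5 carbon, 4 oxygen; one five-membered non-aromatic ring with 1 hetero atom), on a saturated chain carbon bound to a saturated ring carbon and it falls on a saturated chain carbon bound to a saturated ring carbon, where (furan-3-yl)(hydroxy)methyl enters.

Two measured steps exchange the same kinds of group in the opposite direction, both beyond the scatter (an 8.3-fold lower number from compound 1 to compound 2 (0.92 log units; beyond the scatter); a 9.4-fold lower number from compound 1 to compound 3 (0.97 log units; beyond the scatter)). Reversing them points to a higher number. Among the measured compounds shown here, the one measured change at a stereocentre on a saturated chain carbon stayed within the scatter (a 1.1-fold lower number from compound 2 to compound 3 (0.05 log units; within the scatter)), so no separate allowance is made for configuration.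

The step expected in this assay is of similar size to those two steps, estimated as an 8.8-fold higher number from compound 3 to compound 4 (0.94 log units; beyond the scatter) (an expectation, not a measurement).

For compound 4 the expected value is 28000 nM (estimated range 12000 nM to 65000 nM).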

Compound 4, half-maximal inhibitory concentration: 30000 nM
The estimate for compound 4 lay 1.1-fold (0.03 log units) below the measured number; the range from low to high includes it.
By their numbers in this assay, from the lowest: compounds 3 and 2 (each within the scatter of the next); then compounds 1 and 4 (each within the scatter of the next).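

In this assay, the exchange to (furan-3-yl)(hydroxy)methyl now reads in the direction of a weaker result for both compounds carrying the non-aromatic ring, with an 8.3-fold higher number from compound 2 to compound 4 (0.92 log units; beyond the scatter) and a 9.4-fold higher number from compound 3 to compound 4 (0.97 log units; beyond the scatter). At the stereocentre on the saturated chain carbon, the furan-bearing pair behaves as the other pair did, with no change at the digits printed from compound 1 to compound 4 (within the scatter), so configuration at this place does not register with either group, and this reading rests on a pair with nothing else to separate it: the fact that compounds 1 and 4 differ only in the configuration as drawn. The ring exchange therefore accounts for the whole spread among these compounds, and its size holds across the two configurations as drawn: the same change on two cores in this assay, a 9.4-fold lower number (0.97 log units; beyond the scatter) from compound 1 to compound 3 and an 8.3-fold lower number (0.92 log units; beyond the scatter) from compound 4 to compound 2, 1.1-fold (0.05 log units) apart, within the scatter of two such steps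

The compounds shown do not tell which feature of the non-aromatic ring carries the step, as its carbonyl, its ring hydroxyl and its double bond always travel together. Nor do they show whether a carboxylic acid or an amine at this place on the saturated chain carbon would keep the step, or whether configuration stays without effect once the group there is of another kind.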